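Aryl exchange from compound 1 to compound 3: working notes

The source may report more compounds than this note shows. Statements on the series, on what has been measured and on what is new or still open speak of the compounds shown alone.

Compound 1, `Cc1ccccc1-c1cc(F)cc(-n2nnc(-c3ccccn3)n2)c1`: 23 nM
Compound 2, `Fc1cc(-c2ccccn2)cc(-n2nnc(-c3ccccn3)n2)c1`: 95 nM

Going by the values given here, in an assay for binding affinity to metabotropic glutamate receptor 5 (Rattus norvegicus) (a higher number here means a weaker inhibitor, a lower number a stronger inhibitor), compound 1 gives the lower of the two numbers; the single step is a 4.1-fold higher number from compound 1 to compound 2 (0.62 log units; beyond the scatter). Compound 3, `Cc1ccc(-c2cc(F)cc(-n3nnc(-c4ccccn4)n3)c2)cn1`, is not yet measured. It differs from compound 1 by 6-methylpyridin-3-yl in place of 2-methylphenyl on an aromatic carbon. Among the compounds with values here, the only step that bears on this is the one from compound 1 to compound 2, modest and upward. The entering group here is again an aromatic ring with 1 hetero atom, so a weaker upward step is expected: a 2.0-fold higher number from compound 1 to compound 3 (0.29 log units; within the scatter). For compound 3 the estimated value in this assay is 45 nM, with a range of 15 nM to 130 nM.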

Compound 3, inhibition constant: 36 nM
Compound 3: middle estimate off by 1.3-fold (0.10 log units), on the high side; the range from low to high includes it.
By their numbers in this assay, from the lowest: compounds 1 and 3 (each within the scatter of the next); then compound 2.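

In this assay, a ring with 1 hetero atom can hold the level of the 2-methylphenyl compound at this position: a 1.6-fold higher number from compound 1 to compound 3 (0.19 log units; within the scatter). The loss seen with pyridin-2-yl therefore does not follow from a ring nitrogen alone, as a 2.6-fold lower number from compound 2 to compound 3 (0.42 log units; beyond the scatter) shows. Nothing available explains this difference between the two rings.

The compounds shown leave open whether the methyl group or the ring's point of attachment accounts for that difference, which a plain pyridin-3-yl would help separate. Going by these compounds, how a ring carrying a methoxy group or an amine would read here also remains open.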